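Aminothiophene ketone series: fluorination of the aryl piperazine

The source may hold more compounds than are shown below. What is called first, only, known or untested is meant among the compounds shown, and "the series" means these compounds.

Measured so far:
compound 1 `CC(C)N1CCN(Cc2csc(N)c2C(=O)c2ccc(Cl)cc2)CC1` — -7.4%
compound 2 `Nc1scc(CN2CCN(c3ccccc3F)CC2)c1C(=O)c1ccc(Cl)cc1` — -15%

Among the compounds with values here, in a functional assay on CHO cells with adenosine receptor A1 (Homo sapiens) as the target, read by cAMP accumulation and immunoassay, with a stated time of 6 min, tested at 10 uM (a higher number here means a weaker effect of the compound at the concentration tested, a lower number a stronger effect), compound 2 gives -15%, the lower of the two numbers, with compound 1 nearest at -7.4%; the only step, a number 7.6 percentage points lower from compound 1 to compound 2 (within the scatter), lies within the scatter. Compound 3 `Nc1scc(CN2CCN(c3c(F)cccc3F)CC2)c1C(=O)c1ccc(Cl)cc1` carries fluoro in place of hydrogen on an aromatic carbon, that is 2-fluorophenyl to 2,6-difluorophenyl. Within the data shown here, no measured step touches a change of this kind; the one step on record is flat, and both values sit near zero. For compound 3 the expected result in this assay is -12% (-27% to 4%), meaning an estimated step of a number 3 percentage points higher from compound 2 to compound 3 (within the scatter), none beyond the scatter.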

Compound 3, a percentage reported as activity, at one concentration (the size of the read-out at that concentration, not a potency): -80%
Beside the measured number, compound 3's estimate is 68 percentage points above it; the measured number lies below the stated range.
By their numbers in this assay, from the lowest: compound 3; then compounds 2 and 1 (each within the scatter of the next).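

In this assay, within the data shown here, fluoro in place of hydrogen on an aromatic carbon, ortho to a large group and meta to a fluoro group, gives a number 65 percentage points lower from compound 2 to compound 3 (beyond the scatter) and is the first change beyond the scatter. The 2,6-difluorophenyl group in place of isopropyl likewise gives a number 72.6 percentage points lower from compound 1 to compound 3 (beyond the scatter) whereas 2-fluorophenyl in that place stayed within the scatter, so the large effect appears only with the second fluoro. Nothing available accounts for the size of this step. Still open, as far as these compounds go, is whether chloro or methyl at this same position would give a step of similar size, or whether fluoro is required.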